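Urea series on a shared quinoline-type core: aryl swap

A few compounds are considered here, and "the series" means these few. Any claim that something is new, unique, unknown or untested is made for them only; others in the source may bear on it.

Measured so far:
compound 1, `COc1cc(NC(C)CCCNC(=O)Nc2cccc(F)c2)c2ncccc2c1`, 19000 nM
compound 2, `COc1cc(NC(C)CCCNC(=O)Nc2ccc(Br)cc2)c2ncccc2c1`, 18000 nM
compound 3, `COc1cc(NC(C)CCCNC(=O)NNC(=O)Nc2ccc(F)cc2)c2ncccc2c1`, 104000 nM

Values come from a functional assay on L1210 cells (Mus musculus) for inhibition, read by MTT assay, with a stated time of 72 h; on this read-out higher numbers stand for weaker inhibition and lower numbers for stronger inhibition. Compound 2 gives the lowest number of the three, yet compound 1 sits within the scatter of it, so no order between these two can be claimed; compound 3 lies clearly higher, see a 5.8-fold higher number from compound 2 to compound 3 (0.76 log units; beyond the scatter).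

Compound 4, `COc1cc(NC(C)CCCNC(=O)Nc2cccc(O)c2)c2ncccc2c1`, is not yet measured. The change from compound 2 is 3-hydroxyphenyl in place of 4-bromophenyl on an amide-type nitrogen. Within the data shown here, the only step that bears on it is the aryl swap a 1.1-fold lower number from compound 1 to compound 2 (0.02 log units; within the scatter), which was within the scatter; no measured step tests a hydroxyl on the aryl ring. For compound 4 the expected step is therefore a 1.2-fold higher number from compound 2 to compound 4 (0.09 log units; within the scatter), small in either direction, and compound 4 is estimated at 22000 nM with a range from 9000 nM to 55000 nM.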

Compound 4, half-maximal inhibitory concentration: 25000 nM
Compound 4: the middle estimate sits 1.1-fold (0.06 log units) below what was measured; measured number inside the range.
By their numbers in this assay, from the lowest: compounds 2, 1 and 4 (each within the scatter of the next); then compound 3.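

In this assay, a hydroxyl on the aryl ring is now tested on this amide-type nitrogen: a 1.3-fold higher number from compound 1 to compound 4 (0.12 log units; within the scatter) and a 1.4-fold higher number from compound 2 to compound 4 (0.14 log units; within the scatter), so 3-hydroxyphenyl, with its hydrogen-bond donor, cannot be told apart from either halogen-bearing aryl group. The ((4-fluorophenyl)carbamoyl)amino group of compound 3 stays apart from this new aryl group as well, with a 4.2-fold lower number from compound 3 to compound 4 (0.62 log units; beyond the scatter). No accompanying data account for these readings.

Open: whether an amine or a carboxylic acid on the aryl ring, or a longer chain in place of the present one, would move the number beyond the scatter of compound 2.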